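The source may hold more compounds than are shown below. What is called first, only, known or untested is meant among the compounds shown, and "the series" means these compounds.

The series shares the core of compound 1 `CC(C)C[C@@H](N)CN(C(=O)[C@@H]1C[C@H]1c1ccccc1)c1ccc(-c2ccccc2)cc1`, which in a functional assay for agonist activity at G protein-coupled receptor 88 (Homo sapiens), read by HTRF and cAMP accumulation (a lower number here means that less compound is needed, a higher number that more compound is needed for the effect), gives 1.8 nM. Compound 2 `NC1(CN(C(=O)[C@@H]2C[C@H]2c2ccccc2)c2ccc(-c3ccccc3)cc2)CCCC1` gives 0.57 nM in this assay. Going by the values given here, the one measured single-point step, a 3.2-fold lower number from compound 1 to compound 2 (0.50 log units; beyond the scatter), concerns the amine-bearing chain and not the cyclopropane substituent, so it offers no direct guide here. Compound 3 `CC[C@H](C)[C@H](N)CN(C(=O)[C@@H]1C[C@H]1c1ccc(C#N)cc1)c1ccc(-c2ccccc2)cc1` stands at the limit of > 25000 nM in this assay, at which 1 of the 3 values shown sits, and its entry > 25000 nM is a limit, not a number. Compound 4 `CC[C@H](C)[C@H](N)CN(C(=O)[C@@H]1C[C@H]1c1cncnc1)c1ccc(-c2ccccc2)cc1` differs from compound 3 by pyrimidin-5-yl in place of 4-cyanophenyl on a saturated ring carbon. Among the compounds with values here, no measured step touches this position, and with compound 3 at the limit the size of the step cannot be read from the data. The expected step is an at least 1.2-fold lower number from compound 3 to compound 4 (0.09 log units; that floor lies within the scatter), with no direction established. In this assay compound 4 is estimated at 20000 nM, within 2000 nM to 60000 nM.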

Compound 4, half-maximal effective concentration: 19000 nM
Estimate against measurement, compound 4: 1.1-fold (0.02 log units) above, within the range that was stated.
By their numbers in this assay, from the lowest: compound 2; then compound 1; then compound 4. At a limit, above all of these: compound 3.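

With pyrimidin-5-yl in place of 4-cyanophenyl on the saturated ring carbon, the position yields a number in this assay: compound 4 gives 19000 nM. The change reads as an at least 1.3-fold lower number from compound 3 to compound 4 (0.11 log units; that floor lies within the scatter), so its true size remains unread and the floor alone establishes no direction. Compound 3 stands at a limit, not a number: the limit of > 25000 nM in this assay, at which 1 of the 4 values shown sits.

Open, on these data alone, is whether a pyridin-3-yl or 4-methoxyphenyl group on this ring carbon gives a value clear of the scatter from compound 4. Also open, as far as these compounds go, is how pyrimidin-5-yl reads with the 1-aminocyclopentyl chain of compound 2.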